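Swapping the Branched Alkyl for a Cyclohexylethyl Group

The source may hold more compounds than are shown below. What is called first, only, known or untested is meant among the compounds shown, and "the series" means these compounds.

Compound 1 `CC(/N=c1\c(O)c(O)\c1=N/c1ccc(S(N)(=O)=O)cc1)C(C)(C)C` in a functional assay for inhibition, with Rattus norvegicus as the target; on this read-out lower numbers stand for stronger inhibition and higher numbers for weaker inhibition: > 30000 nM, which is a limit of the assay and not a number.
Compound 2 `CC(/N=c1\c(O)c(O)\c1=N/c1ccc(C#N)cc1)C(C)(C)C` in this assay: 520 nM.

Within the data shown here, compound 2 holds the only actual number in this assay; the other value is a limit (the limit of > 30000 nM in this assay, at which 1 of the 2 values shown sits). Among the measured compounds shown here, the single measured step, an at least 57-fold lower number from compound 1 to compound 2 (1.76 log units; beyond the scatter), is large, but it concerns the group on the aromatic ring and not the group on the double-bonded nitrogen.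

Compound 3 `C[C@@H](/N=c1\c(O)c(O)\c1=N/c1ccc(C#N)cc1)C1CCCCC1` is not yet measured. It differs from compound 2 in one place: 1-cyclohexylethyl in place of 1,2,2-trimethylpropyl on a double-bonded nitrogen. For the measured compounds named here, no measured step touches this position, so there is no basis for expecting a change beyond the scatter in either direction in this assay.

Compound 3 is therefore estimated at 520 nM, within a range of 150 nM to 1800 nM, an expected step of no change at the digits printed from compound 2 to compound 3 (within the scatter).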

Compound 3, half-maximal inhibitory concentration: 2600 nM
Compound 3: middle estimate off by 5.0-fold (0.70 log units), on the low side, and the stated range ends below it.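

The group on the double-bonded nitrogen does affect the read-out in this assay: 1-cyclohexylethyl in place of 1,2,2-trimethylpropyl gives a 5.0-fold higher number from compound 2 to compound 3 (0.70 log units; beyond the scatter), which means modestly weaker inhibition. Among these compounds, the earlier compounds showed a change only on the aromatic ring, so this is the first sign that this second position also responds, and that the branched open chain serves better here than this ring-bearing group, at least for this one pair. Nothing shown here accounts for the weaker inhibition.

The new group differs from the old one in size, in carrying a ring and in having a defined stereocentre, and this single step cannot separate those differences. On these data alone, it remains open how a plain cyclohexyl, a 1-phenylethyl or the mirror-image form of 1-cyclohexylethyl would compare in this assay.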